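The compounds below may be only part of what the source reports. "The series", "measured", "known", "first", "only" and "open" are said of these compounds alone.

Compound 3 `O=[N+]([O-])c1cn2c(n1)OC[C@@H](OCc1cc(-c3ccc(F)cc3)no1)C2` was tested in an ADME assay on Vero cells (Chlorocebus sabaeus) for cytotoxicity, with a stated time of 72 h (a lower number here means a stronger inhibitor, a higher number a weaker inhibitor), and gave only a limit, > 128000 nM. Compound 1 `O=[N+]([O-])c1cn2c(n1)OC[C@@H](OCc1cc(-c3ccc(C(F)(F)F)cc3)no1)C2`, in this assay, likewise gave the limit > 128000 nM. Compound 2 `N#Cc1ccc(-c2cc(CO[C@@H]3COc4nc([N+](=O)[O-])cn4C3)on2)cc1` also returned a limit, > 128000 nM. Every value shown so far thus sits at the limit of > 128000 nM in this assay, at which 3 of the 3 values shown sit, and the three steps between these compounds, a step that the two limits leave unreadable from compound 1 to compound 2, a step that the two limits leave unreadable from compound 1 to compound 3 and a step that the two limits leave unreadable from compound 2 to compound 3, cannot be sized from such numbers. Compound 4 `O=[N+]([O-])c1cn2c(n1)OC[C@@H](OCc1cc(-c3ccc(OC(F)(F)F)cc3)no1)C2` differs from compound 3 in one place: trifluoromethoxy in place of fluoro on an aromatic carbon. The measured steps that bear on this change are all exchanges of a small group on an aromatic carbon, and each of them is unreadable, so they give neither a direction nor a size beyond the usual scatter. Compound 4 is therefore expected to remain at the limit as well, with an expected step of a number no higher from compound 3 to compound 4 (the limit leaves the size open). The estimate for compound 4 in this assay is 128000 nM, with a range from 64000 nM to 256000 nM.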

Compound 4, half-maximal inhibitory concentration: > 128000 nM
Compound 4: a limit, no number (the forecaster's own chance of this, stated with the estimate: 85%); the middle value lies on the limit itself.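

In this assay compound 4 also gave only a limit, so its steps to compound 1, compound 2 and compound 3 cannot be read. The compounds shown leave open whether exchanging these groups on the aromatic carbon changes the value at all, with every result sitting at one ceiling: the limit of > 128000 nM in this assay, at which 4 of the 4 values shown sit.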